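From a difluorophenyl group to a carbon-only ring

The source may report more compounds than this note shows. Statements on the series, on what has been measured and on what is new or still open speak of the compounds shown alone.

Measured in an ADME assay on MDBK cells (Bos taurus) for cytotoxicity, read by MTT assay; on this read-out lower numbers stand for higher toxicity in this test and higher numbers for lower toxicity in this test:
- compound 1 `OC[C@@H]1[C@@H](O)[C@H](O)[C@@H](O)CN1CCCCCCOc1cc(F)ccc1F` gives > 500000 nM
- compound 2 `OC[C@@H]1[C@@H](O)[C@H](O)[C@@H](O)CN1CCCc1cccc(OC2CCCCC2)c1` gives 390000 nM
- compound 3 `Cc1ccc(C(C)(C)C)c(OCCCCCCN2C[C@H](O)[C@@H](O)[C@H](O)[C@H]2CO)c1` gives 85000 nM

Compound 1 reaches only a limit of the assay, > 500000 nM, and not a number. Among the measured compounds shown here, its true position therefore remains open, and no compound among the three can be placed against it by an exact gap.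

Compound 4 `CC1CCCC(OCCCCCCN2C[C@H](O)[C@@H](O)[C@H](O)[C@H]2CO)C1C` has not yet been measured. It differs from compound 1 in one place (a group of 8 heavy atoms (8 carbon; one six-membered non-aromatic ring of carbon only) in place of a group of 8 heavy atoms (6 carbon, 2 fluorine; one six-membered aromatic ring of carbon only), on an oxygen on a saturated carbon), with the new group on the same oxygen on a saturated carbon. For the measured compounds named here, no pair of measured compounds differs in only one place, so the size of this change has no direct precedent here.

The expectation rests on the two fluorine-free compounds. Compound 2 gives 390000 nM, and compound 3 gives 85000 nM. Both are numbers rather than limits, so compound 4 is expected to give a number too, lower than the limit of compound 1 and thus to be more toxic in this assay. The expected change is an at least 2.9-fold lower number from compound 1 to compound 4 (0.46 log units; beyond the scatter).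

For compound 4 the estimated half-maximal cytotoxic concentration is 170000 nM, with an expected range from 60000 nM to 480000 nM.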

Compound 4, half-maximal cytotoxic concentration: > 500000 nM
Compound 4: a limit, no number (the forecaster's own chance of this, stated with the estimate: 15%); middle value at least 2.9-fold (0.46 log units) from the limit.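

In this assay compound 4 gives > 500000 nM as a limit of the assay and not a number. Among the compounds shown here, compound 1 also stands at a limit, so no step from it to compound 4 can be read: the limit of > 500000 nM in this assay, at which 2 of the 4 values shown sit. The compounds shown leave open whether replacing the 2,5-difluorophenyl group with the carbon-only ring changes this read-out at all.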